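Swapping an ethyl for difluoromethyl on an amide carbonyl

The compounds below may be only part of what the source reports. "The series", "measured", "known", "first", "only" and "open" are said of these compounds alone.

Measured compounds:
compound 1, `CN1CCN(C[C@H]2CN(c3ccc(-n4cc(-c5ccccn5)cn4)c(F)c3)C(=O)O2)CC1`, 2.2
compound 2, `CCC(=O)NC[C@H]1CN(c2ccc(-n3cc(-c4ccccn4)cn3)c(F)c2)C(=O)O1`, 2.2

Both compounds were read in a physicochemical assay for lipophilicity, read by HPLC, measured as octanol-water partition; on this read-out higher numbers stand for higher lipophilicity and lower numbers for lower lipophilicity. Compound 2 stands level with compound 1 there: the step of no change at the digits printed from compound 1 to compound 2 (within the scatter) shows that exchanging the 4-methylpiperazin-1-yl of compound 1 for the propanoylamino of compound 2 left the read-out unchanged within the scatter.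

Compound 3, `O=C(NC[C@H]1CN(c2ccc(-n3cc(-c4ccccn4)cn3)c(F)c2)C(=O)O1)C(F)F`, has not yet been measured. It differs from compound 2 in one place: difluoromethyl in place of ethyl on a carbonyl carbon. For the measured compounds named here, the only measured step available, from compound 1 to compound 2, concerns a different kind of exchange on the saturated chain carbon, not on the carbonyl carbon, so no measured step of the present kind exists to guide a prediction. The change is small in count, two heavy atoms leaving and three entering, with no rings, donors, acceptors or charge involved.

For compound 3 a step of about a number 0.20 log units lower from compound 2 to compound 3 (within the scatter) is expected in this assay, amounting to little or no change beyond the scatter. Compound 3 is therefore estimated at 2, with a range from 1.6 to 2.4.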

Compound 3, partition coefficient: 1.9
For compound 3 the middle estimate is 0.10 log units above the measured one, within the range that was stated.
By their numbers in this assay, from the lowest: compounds 3, 1 and 2 (each within the scatter of the next).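

In this assay, the exchange of ethyl for difluoromethyl on a carbonyl carbon, whose other neighbour is an amide-type nitrogen, now has a measured step of its own, which reads a number 0.30 log units lower from compound 2 to compound 3 (within the scatter). The larger exchange on the saturated chain carbon, with ((difluoromethyl)carbonyl)amino in place of 4-methylpiperazin-1-yl, reads a number 0.30 log units lower from compound 1 to compound 3 (within the scatter), so every pair among the three compounds now lies within the scatter of this assay, and none of them goes against that. Nothing further is at hand that could explain this result, which therefore stands as a plain observation.

Still open, on these data alone, is whether other groups on the same carbonyl carbon, such as trifluoromethyl, a longer chain like butyl, or a chain ending in an amine or a carboxylic acid, would also stay within the scatter of compound 2 or would move clearly away from it. Also open is whether the exchange of ethyl for difluoromethyl would read the same way on a carbonyl carbon in a different core, since this single pair of compounds speaks only for the shared core shown here.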